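The source may report more compounds than this note shows. Statements on the series, on what has been measured and on what is new or still open speak of the compounds shown alone.

Compound 1 `C[C@@H]1CN(C(=O)OC(C)(C)C)CCN1c1ncc(OCC2CCN(S(C)(=O)=O)CC2)cn1`: in an in vitro functional assay on HEK293S cells with Glucose-dependent insulinotropic receptor (Homo sapiens) as the target, read by HTRF and cAMP accumulation, with a stated time of 45 min (on this read-out lower numbers stand for smaller maximal responses and higher numbers for larger maximal responses), compound 1 gives 99%.
Compound 2 `C[C@@H]1CN(C(=O)OC(C)(C)C)CCN1c1ncc(OCc2ccc(C#N)cc2)cn1`: in this assay compound 2 gives 141%.

Among the two measured values, compound 2 stands highest. Within the data shown here, the only step measured, a number 42 percentage points higher from compound 1 to compound 2 (beyond the scatter), shows that exchanging the group at this place can move the maximal response a great deal. Compound 3 `C[C@@H]1CN(C(=O)OC(C)(C)C)CCN1c1ncc(OCc2ccc(S(C)(=O)=O)cc2F)cn1` carries 2-fluoro-4-(methylsulfonyl)phenyl in place of 4-cyanophenyl on a saturated chain carbon bound to an oxygen on an aromatic ring. Among the measured compounds shown here, no step of this exact kind has been measured, so the direction rests on little. For compound 3 a moderate step back toward the middle is expected, a number 21 percentage points lower from compound 2 to compound 3 (beyond the scatter). Compound 3 is therefore estimated at 120%, within a range from 90% to 150%.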

Compound 3, intrinsic activity: the largest response reached, in percent of the reference agonist's: 149%
Compound 3: middle estimate off by 29 percentage points, on the low side, within the range that was stated.
By their numbers in this assay, from the lowest: compound 1; then compounds 2 and 3 (each within the scatter of the next).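

In this assay, 2-fluoro-4-(methylsulfonyl)phenyl in place of 4-cyanophenyl gives a number 8 percentage points higher from compound 2 to compound 3 (within the scatter), so these two aromatic groups cannot be told apart at this place. In place of 1-(methylsulfonyl)piperidin-4-yl, the same group gives a number 50 percentage points higher from compound 1 to compound 3 (beyond the scatter), so the large gain now appears with a second substituted phenyl group, and a methylsulfonyl group is present on both sides of this step. No measurement at hand offers a reason for these numbers. On these data alone, the fluorine and the methylsulfonyl group enter together, so their separate contributions stay open. Also open, as far as these compounds go, is whether a phenyl ring carrying an amine or a carboxylic acid would reach a similar maximal response.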